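Removing the Chloro Group from Compound 2

The compounds below may be only part of what the source reports. "The series", "measured", "known", "first", "only" and "open" are said of these compounds alone.

Of the compounds shown here, two have been measured in a functional assay on U-251 cells (Homo sapiens) for antiproliferative activity, read by sulforhodamine B assay, with a stated time of 48 h; a lower number here means a stronger inhibitor of growth, a higher number a weaker inhibitor of growth. Compound 1 `COc1ccc(OC)c(/C=C/c2nnc(Nc3ccc(Cl)cc3)o2)c1` gives 14300 nM in this assay. Compound 2 `COc1ccc(OC)c(/C=C/C(=O)N/N=C/c2ccc(Cl)cc2)c1` gives 1490 nM in this assay and stands at the lower of the two numbers; the gap to compound 1 is beyond the scatter. For the measured compounds named here, the two compounds differ in more than one place, so no single step between measured compounds is available, and nothing measured here shows what a change at the chlorinated ring alone does.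

Compound 3 `COc1ccc(OC)c(/C=C/C(=O)N/N=C/c2ccccc2)c1` differs from compound 2 by hydrogen in place of chloro on an aromatic carbon, in words hydrogen in place of chloro on an aromatic carbon; cut one bond further out, the difference reads 4-chlorophenyl to phenyl. Going by the values given here, with no measured step of this kind to lean on, the account expects the step of a 2.3-fold higher number from compound 2 to compound 3 (0.37 log units; beyond the scatter) to be small, in the direction of a weaker inhibitor of growth, and likely within or close to the scatter. Compound 3 is estimated to give 3500 nM in this assay, with a range from 1200 nM to 12000 nM.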

Compound 3, concentration for total growth inhibition: > 100000 nM
Compound 3: no number, only a limit (the forecaster's own chance of this, stated with the estimate: 10%); middle value at least 28-fold (1.45 log units) away from the limit.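

For the compounds shown here, the step from the chlorinated ring is the first single change that can be read. Hydrogen in place of chloro, on an aromatic carbon para to a large group, gives an at least 67-fold higher number from compound 2 to compound 3 (1.82 log units; beyond the scatter) in this assay, so in this pair the growth inhibition seen with compound 2 depends strongly on what sits at this position. In this assay compound 3 gives > 100000 nM, which is a limit of the assay and not a number: the limit of > 100000 nM in this assay, at which 1 of the 3 values shown sits. The step is therefore a minimum, and it rests on this one pair alone, with compound 1 differing from both compounds in more than one place.

The compounds shown leave open whether chloro itself matters here or whether another group at the same position, such as fluoro, bromo, methyl or methoxy, would keep the number near that of compound 2. They also leave open whether the same loss would follow from replacing chloro with hydrogen on the 4-chlorophenyl group of compound 1, whose core is different.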